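The compounds below may be only part of what the source reports. "The series", "measured", "known", "first", "only" and "open" are said of these compounds alone.

Measured so far in a functional assay on A549 cells (Homo sapiens) for inhibition, read by MTT assay, with a stated time of 72 h, tested at 10 uM; on this read-out lower numbers stand for less inhibition and higher numbers for more inhibition at the one concentration tested (going by the name of the read-out):
compound 1, `CCOC(=O)C1=C(Nc2ccccc2)S/C(=C\c2ccc(O)c(O)c2)C1=O`, gives 30.7%
compound 2, `CCOC(=O)C1=C(Nc2ccc(OC)cc2)S/C(=C\c2ccc[nH]2)C1=O`, gives < 10%

Going by the values given here, compound 1 is the only compound of the pair that returns an actual number in this assay. Compound 2 stands at a limit of this assay and not at a number, and this is the whole of what is known of it, as the limit of < 10% in this assay, at which 1 of the 2 values shown sits, records. Among the compounds with values here, with only one number and one limit in hand, no measured step between the two compounds can be stated, and the two structures differ in more than one place, so nothing beyond their two values is said of them together.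

Compound 3, `CCOC(=O)C1=C(Nc2ccccc2)S/C(=C\c2cccnc2)C1=O`, is not yet measured. It differs from compound 1 by pyridin-3-yl in place of 3,4-dihydroxyphenyl on a double-bonded chain carbon bound to a double-bonded ring carbon. Within the data shown here, since no measured step covers this change, the expectation rests on the two values alone. The step from compound 1 to compound 3 is expected to be a loss of inhibition larger than the usual scatter, a number 15.7 percentage points lower from compound 1 to compound 3 (beyond the scatter). Compound 3 is therefore estimated at 15%, with a range from 5% to 30%, and a fair chance that this assay returns only its limit.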

Compound 3, a percentage reported as inhibition, at one concentration (the size of the read-out at that concentration, not a potency): < 10%
Compound 3 gave a limit, no number (the forecaster's own chance of this, stated with the estimate: 40%); middle value at least 5 percentage points away from the limit.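

In this assay, going by these compounds alone, pyridin-3-yl in place of 3,4-dihydroxyphenyl on a double-bonded chain carbon bound to a double-bonded ring carbon gives a number at least 20.7 percentage points lower from compound 1 to compound 3 (beyond the scatter), and this is the only measured step so far. Compound 3 gives < 10%, which is a limit of the assay and not a number, so the step has a minimum size but no known full size. This position therefore matters for the read-out on the core of compound 1, and among the compounds shown, a measured number appears only with 3,4-dihydroxyphenyl at this place, while the rest sit at the limit: the limit of < 10% in this assay, at which 2 of the 3 values shown sit.

The change removes both hydroxyl groups and puts a ring nitrogen in place of a ring carbon in one move, so the compounds shown do not tell which of these accounts for the step. Unsubstituted phenyl, phenyl with a single hydroxyl group, or dimethoxyphenyl at this place would separate the two, and whether the anilino group and the ethyl ester of compound 1 can vary with the 3,4-dihydroxyphenyl group kept also remains open.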